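Swapping Chloro for Hydroxy on Compound 3

The source may report more compounds than this note shows. Statements on the series, on what has been measured and on what is new or still open speak of the compounds shown alone.

Compound 1 `COc1cc(-n2cnc3ccc(-c4ccccc4Cl)cc32)cc(OC)c1OC` gives only a limit in a functional assay on A549 cells (Homo sapiens) for antiproliferative activity, read by MTT assay, with a stated time of 72 h (a lower number here means a stronger inhibitor, a higher number a weaker inhibitor), > 10000 nM. Compound 2 `COc1cc(-n2cnc3ccc(-c4ccc([N+](=O)[O-])cc4)cc32)cc(OC)c1OC` gives 8940 nM in this assay. Within the data shown here, compound 3 `COc1cc(-n2cnc3ccc(-c4cccc(Cl)c4)cc32)cc(OC)c1OC` gives 7050 nM, so it is one of only two compounds here with a true number, and those two numbers cannot be told apart: the measured change is a 1.3-fold lower number from compound 2 to compound 3 (0.10 log units; within the scatter).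

Compound 4 `COc1cc(-n2cnc3ccc(-c4cccc(O)c4)cc32)cc(OC)c1OC` differs from compound 3 by a single exchange, (hydroxy in place of chloro on an aromatic carbon). This places hydroxy in place of chloro on an aromatic carbon, turning 3-chlorophenyl into 3-hydroxyphenyl.

The measured steps that bear on this exchange also replace one substituted phenyl group with another. Besides the step above, there is an at least 1.4-fold lower number from compound 1 to compound 3 (0.15 log units; that floor lies within the scatter), and there is an at least 1.1-fold lower number from compound 1 to compound 2 (0.04 log units; that floor lies within the scatter). Neither of these two shows a change beyond the scatter, though both rest on a limit and not on a number. None of the steps involves a hydroxy group, so they offer only loose guidance. The expected result is no shift beyond the scatter, with the estimate being a 1.1-fold lower number from compound 3 to compound 4 (0.04 log units; within the scatter). For compound 4 the estimated value is 6500 nM, with an expected range from 2000 nM to 10000 nM.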

Compound 4, half-maximal inhibitory concentration: 250 nM
Compound 4: middle estimate off by 26-fold (1.41 log units), on the high side; the measured number lies below the stated range.
By their numbers in this assay, from the lowest: compound 4; then compounds 3 and 2 (each within the scatter of the next). At a limit, above all of these: compound 1.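

In this assay, among these compounds, this exchange on an aromatic carbon, meta to a large group, gives the first large change: a 28-fold lower number from compound 3 to compound 4 (1.45 log units; beyond the scatter), a step beyond the scatter, while the step between compound 2 and compound 3 stays within it. So a change of one heavy atom at this position, bringing in one hydrogen-bond donor and one hydrogen-bond acceptor where chloro had none, can matter far more than the earlier phenyl swaps suggested, and the same separation appears against the 4-nitrophenyl compound, with a 36-fold lower number from compound 2 to compound 4 (1.55 log units; beyond the scatter). The step of an at least 40-fold lower number from compound 1 to compound 4 (1.60 log units; beyond the scatter) is also beyond the scatter, but its size is only a floor, as it starts from a limit and not from a number: the limit of > 10000 nM in this assay, at which 1 of the 4 values shown sits.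

The compounds shown do not say whether the large step belongs to hydroxy alone or would also appear with an amine or a carboxylic acid on the same carbon. They also leave open whether hydroxy would give the same result at another place on this ring, and nothing here measures why the exchange has so large an effect.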